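Hydroxyphenyl for chlorophenyl on the saturated ring carbon

This account rests on a few compounds, and the source may have more. Where it says the series, first, only, none or still open, it means among the compounds named here.

Working notes on a small series sharing one core. Compound 1 `Cc1ccc(C)n1-c1ccc(C(=O)N/N=C/c2ccc(N(C)C)cc2)cc1`, compound 2 `CC(=O)N1N=C(c2ccc(-n3c(C)ccc3C)cc2)OC1c1ccccc1Cl` and compound 3 `Cc1ccc(C)n1-c1ccc(-c2n[nH]c(=S)n2N)cc1` have been run in an ADME assay on A549 cells (Homo sapiens) for cytotoxicity, read by MTT assay, with a stated time of 72 h; a lower number here means a stronger inhibitor, a higher number a weaker inhibitor. For compound 1 the entry reads "not determined" (no result reported), so no number is available. In this assay compound 2 gives 206000 nM, the higher of the two numbers recorded, while compound 3 gives 170000 nM, a gap that sits within the scatter; compound 2 and compound 3 therefore cannot be ordered against each other. Among the measured compounds shown here, no pair of measured compounds differs in a single place, so no step has been measured.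

The next compound, compound 4 `CC(=O)N1N=C(c2ccc(-n3c(C)ccc3C)cc2)OC1c1ccc(O)cc1`, differs from compound 2 in one place: 4-hydroxyphenyl in place of 2-chlorophenyl on a saturated ring carbon

For the measured compounds named here, with no measured single-point step to lean on, and with the two numbers in hand within the scatter of each other, the expectation for the step in this assay is none beyond the scatter, with a weakly higher number as the more probable side. The expected step is a 1.1-fold higher number from compound 2 to compound 4 (0.05 log units; within the scatter). Compound 4 is estimated at 230000 nM, with a range from 100000 nM to 500000 nM.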

Compound 4, half-maximal inhibitory concentration: 190000 nM
The estimate for compound 4 lay 1.2-fold (0.08 log units) above the measured number; the range from low to high includes it.
By their numbers in this assay, from the lowest: compounds 3, 4 and 2 (each within the scatter of the next).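

In this assay, the swap of 2-chlorophenyl for 4-hydroxyphenyl on the saturated ring carbon gives a 1.1-fold lower number from compound 2 to compound 4 (0.04 log units; within the scatter), the first single-place step measured in this series. Compound 2 and compound 4 therefore cannot be ordered against each other, even though the entering group carries a hydrogen-bond donor and a hydrogen-bond acceptor that the leaving group lacks, and the two groups differ in where the phenyl ring bears its substituent. Nothing measured on these compounds bears on why this step stays within the scatter.

This single pair changes the substituent and its place on the phenyl ring together, so 4-chlorophenyl and 2-hydroxyphenyl at this carbon would be needed to read the two apart. Also open, as far as these compounds go, is whether a group of another kind on the same carbon, such as an aminomethyl group or a carboxylic acid, or the acetyl group on the ring nitrogen exchanged for a longer acyl chain, would give a step beyond the scatter.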